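Compound 1 to compound 3: stability in mouse liver microsomes

The source may report more compounds than this note shows. Statements on the series, on what has been measured and on what is new or still open speak of the compounds shown alone.

Measured so far in an ADME assay on microsomes from liver (Mus musculus) for metabolic stability, with a stated time of 10 min; a lower number here means that less of the compound is left, a higher number that more of the compound is left:
Compound 1 `O=C(O)[C@H]1CC[C@](F)(C(=O)N2CC[C@](c3ccc(C(F)(C(F)(F)F)C(F)(F)F)cc3)(S(=O)(=O)c3ccc(F)cc3)C2)CC1`: "not determined" (no result reported)
Compound 2 `O=C1NC(=O)C2(CCC(C(=O)N3CC[C@](c4ccc(C(F)(C(F)(F)F)C(F)(F)F)cc4)(S(=O)(=O)c4ccc(F)cc4)C3)CC2)N1`: 81%; 82% (2 entries)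

Compound 1 has no single number in this assay, and its entry reads "not determined" (no result reported) with no result behind it. The series therefore has no baseline at the start of this step. Among the measured compounds shown here, the only numerical anchor is compound 2, whose repeat entries lie close together (the several entries of compound 2 in this assay, 81%; 82% (2 entries)).

Compound 3 `NC(=O)[C@H]1CC[C@H](C(=O)N2CC[C@](c3ccc(C(F)(C(F)(F)F)C(F)(F)F)cc3)(S(=O)(=O)c3ccc(F)cc3)C2)CC1` keeps the core of compound 1 but carries 4-carbamoylcyclohexyl in place of 4-carboxy-1-fluorocyclohexyl on a carbonyl carbon. The same position in compound 2 holds a different group, so that compound is only a loose guide.

With no number for compound 1, the data fix neither the size nor the direction of the step, and no step beyond the scatter is assumed. The expectation rests on compound 2 at 81%; 82% (2 entries) and is set somewhat lower with a wide range to reflect this weak anchor. Compound 3 is expected at 72% in this assay, with an estimated range from 50% to 90% for the measurement.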

Compound 3, percent of the compound remaining: 100%
Estimate against measurement, compound 3: 28 percentage points below; the whole stated range lies below it.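

In this assay, among the compounds shown here, compound 3 gives 100% but compound 1 has no single number, and no step from compound 1 to compound 3 can be read. The compounds shown leave open how far, and in which direction, 4-carbamoylcyclohexyl in place of 4-carboxy-1-fluorocyclohexyl on the carbonyl carbon shifts the percent of compound remaining.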